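The source may report more compounds than this note shows. Statements on the series, on what has been measured and on what is new or still open speak of the compounds shown alone.

Working notes on the series. The shared core carries a bis(trifluoromethyl)carbinol and an aminopyridinyl sulfonylpiperazine; the variable arm sits on an aromatic carbon of the six-membered ring with one nitrogen. Compound 1 `Nc1ccc(S(=O)(=O)N2CCN(c3ncc(C(O)(C(F)(F)F)C(F)(F)F)cc3C#CC3CC3)CC2)cn1` bears 2-cyclopropylethynyl there. In an ADME assay (liver) for metabolic stability, with Liver microsome (Homo sapiens) as the target, using microsomes and NADPH, with a stated time of 30 min, tested at 1 uM (on this read-out lower numbers stand for slow clearance and higher numbers for fast clearance), compound 1 gives a limit of < 14 mL.min-1.g-1 (the limit of < 14 mL.min-1.g-1 in this assay, at which 1 of the 3 values shown sits). Compound 2 `CCn1cc(-c2cc(C(O)(C(F)(F)F)C(F)(F)F)cnc2N2CCN(S(=O)(=O)c3ccc(N)nc3)CC2)cn1` carries 1-ethyl-1H-pyrazol-4-yl and in this assay compound 2 gives 20 mL.min-1.g-1. Compound 3 `CC(C)n1cc(-c2cc(C(O)(C(F)(F)F)C(F)(F)F)cnc2N2CCN(S(=O)(=O)c3ccc(N)nc3)CC2)cn1` carries 1-isopropyl-1H-pyrazol-4-yl; in this assay compound 3 gives 38 mL.min-1.g-1. The steps are an at least 1.4-fold higher number from compound 1 to compound 2 (0.15 log units; that floor lies within the scatter), an at least 2.7-fold higher number from compound 1 to compound 3 (0.43 log units; beyond the scatter) and a 1.9-fold higher number from compound 2 to compound 3 (0.28 log units; within the scatter), so compound 2 and compound 3 sit within scatter of each other and only compound 3 stands clearly apart from the limit of compound 1.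

Compound 4 `Nc1ccc(S(=O)(=O)N2CCN(c3ncc(C(O)(C(F)(F)F)C(F)(F)F)cc3-c3cccnc3)CC2)cn1` differs from compound 2 by pyridin-3-yl in place of 1-ethyl-1H-pyrazol-4-yl on an aromatic carbon. Among the compounds with values here, no measured step swaps one aromatic arm for another of this kind; the two pyrazole steps from compound 1 were small to modest. No step beyond the scatter is therefore expected in this assay, with a slight lean toward slower clearance. Compound 4 is expected to give 16 mL.min-1.g-1, between 7 mL.min-1.g-1 and 36 mL.min-1.g-1, that is a 1.3-fold lower number from compound 2 to compound 4 (0.10 log units; within the scatter).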

Compound 4, intrinsic clearance in microsomes: 17 mL.min-1.g-1
Estimate against measurement, compound 4: 1.1-fold (0.03 log units) below; measured number inside the range.
By their numbers in this assay, from the lowest: compounds 4, 2 and 3 (each within the scatter of the next, the first and the last beyond it). At a limit, below all of these: compound 1.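

Replacing the five-membered aromatic arm with a six-membered one at this position gives a 1.2-fold lower number from compound 2 to compound 4 (0.07 log units; within the scatter), so in this assay the change of ring leaves the number within the scatter. Against the isopropyl-bearing arm, the same pyridin-3-yl gives a 2.2-fold lower number from compound 3 to compound 4 (0.35 log units; beyond the scatter), the only gap here between two numbers that lies beyond the scatter. The remaining step, an at least 1.2-fold higher number from compound 1 to compound 4 (0.08 log units; that floor lies within the scatter), rests on a limit and gives only a floor: the limit of < 14 mL.min-1.g-1 in this assay, at which 1 of the 4 values shown sits.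

Open, as far as these compounds go, is how a pyridin-3-yl arm carrying a methoxy group or a primary amine would read in this assay. Also open, from the compounds shown here alone, is whether a saturated ring in this place would follow the aromatic arms.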